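The source may hold more compounds than are shown below. What is called first, only, known or untested is meant among the compounds shown, and "the series" means these compounds.

Measured so far in an ADME assay on NIH3T3 cells (Mus musculus) for cytotoxicity, read by MTT assay, with a stated time of 24 h; on this read-out lower numbers stand for stronger inhibition and higher numbers for weaker inhibition:
compound 1 `Cc1nnc(SCC(=O)N/N=c2/scc(-c3ccc(F)cc3)n2-c2ccccc2)s1`: 383 ug/mL
compound 2 `Cn1cnnc1SCC(=O)N/N=c1/scc(-c2ccc(F)cc2)n1-c1ccccc1`: 65 ug/mL
compound 3 `O=C(CSc1ncccn1)N/N=c1/scc(-c2ccc(F)cc2)n1-c1ccccc1`: reported only as a limit, > 500 ug/mL

Compound 1 holds the highest of the two numbers shown; its nearest neighbour is compound 2, a 5.9-fold lower number from compound 1 to compound 2 (0.77 log units; beyond the scatter). Compound 3 sits at a limit of this assay, (the limit of > 500 ug/mL in this assay, at which 1 of the 3 values shown sits), and gives no number to compare.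

Compound 4 `Cc1ccc(-c2cs/c(=N/NC(=O)CSc3nnc(C)s3)n2-c2ccccc2)cc1` differs from compound 1 by methyl in place of fluoro on an aromatic carbon. Every measured step in the series replaces the ring on the sulfur; none alters the 4-fluorophenyl, so none bears on this change. No step beyond the scatter is expected in this assay for compound 4, and the estimate is 380 ug/mL, range 170 ug/mL to 500 ug/mL, that is a 1.0-fold lower number from compound 1 to compound 4 (0.00 log units; within the scatter), with a real chance that only a limit is reported.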

Compound 4, half-maximal inhibitory concentration: 373 ug/mL
For compound 4 the middle estimate is 1.0-fold (0.01 log units) above the measured one; measured number inside the range.
By their numbers in this assay, from the lowest: compound 2; then compounds 4 and 1 (each within the scatter of the next). At a limit, above all of these: compound 3.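

In this assay the change from 4-fluorophenyl to 4-methylphenyl gives a 1.0-fold lower number from compound 1 to compound 4 (0.01 log units; within the scatter), the only step shown that leaves the ring on the sulfur untouched. With the 5-methyl-1,3,4-thiadiazol-2-yl kept, fluoro and methyl at this position are not told apart, while the ring change on the sulfur gives a 5.9-fold lower number from compound 1 to compound 2 (0.77 log units; beyond the scatter). Nothing measured on these compounds bears on this result.

Open, as far as these compounds go, is how an amine, a carboxylic acid or a methoxy would read at this position. Also open, from the compounds shown here alone, is whether fluoro and methyl stay level with the 4-methyl-4H-1,2,4-triazol-3-yl of compound 2 on the sulfur.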